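Sulfoxide series: amide in place of the methoxy ether

A few compounds are considered here, and "the series" means these few. Any claim that something is new, unique, unknown or untested is made for them only; others in the source may bear on it.

Among the measured compounds shown here, compound 2 `COCC[S+]([O-])CC1CN(C)CCC1c1ccc(Cl)cc1` gives 15 nM in an assay on isolated protein for inhibition of sodium-dependent dopamine transporter (Rattus norvegicus), read by radioligand binding (a higher number here means a weaker inhibitor, a lower number a stronger inhibitor), the lowest of the two numbers so far; compound 1 `COCCSCC1CN(C)CCC1c1ccc(Cl)cc1` gives 50 nM, and the step of a 3.3-fold lower number from compound 1 to compound 2 (0.52 log units; beyond the scatter) lies beyond the scatter. Compound 3 `CN1CCC(c2ccc(Cl)cc2)C(C[S+]([O-])CC(=O)N(C)C)C1` carries dimethylcarbamoyl in place of methoxymethyl on a saturated chain carbon bound to a sulfur. For the measured compounds named here, no measured step touches this part of the chain; the only step available changes a different part of the molecule and gives no guide here. The expectation is therefore a step of a 1.3-fold higher number from compound 2 to compound 3 (0.12 log units; within the scatter), not beyond the scatter in either direction. Compound 3 is estimated at 20 nM, with a range from 6 nM to 70 nM.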

Compound 3, inhibition constant: 2880 nM
Beside the measured number, compound 3's estimate is 140-fold (2.16 log units) below it; measured number above the stated range.
By their numbers in this assay, from the lowest: compound 2; then compound 1; then compound 3.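

This position on the sulfoxide chain, the saturated chain carbon bound to a sulfur, is highly sensitive to the group it carries in this assay: dimethylcarbamoyl in place of methoxymethyl gives a 190-fold higher number from compound 2 to compound 3 (2.28 log units; beyond the scatter). The earlier step changed only the sulfur and gave no reading of this end of the chain. No data on the reason for this step are at hand.

The compounds shown do not separate the carbonyl from its two methyl groups on nitrogen; a primary amide or a simple methyl ketone here would do so. From the compounds shown here alone, how an amine or a longer ether chain behaves at this position also remains open.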